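Trifluoromethyl in place of methyl: the step from compound 2

This account rests on a few compounds, and the source may have more. Where it says the series, first, only, none or still open, it means among the compounds named here.

Measured in a functional assay (aorta) with Rattus norvegicus as the target; a lower number here means that less compound is needed, a higher number that more compound is needed for the effect:
compound 1 `C/N=C(/S)C1=CC(C)(C)Oc2ccc([N+](=O)[O-])cc21`: 1.35 nM
compound 2 `CNC(=O)C1=CC(C)(C)Oc2ccc([N+](=O)[O-])cc21`: 10.7 nM

Of these two numbers, the higher belongs to compound 2. Compound 3 `CNC(=O)C1=CC(C)(C(F)(F)F)Oc2ccc([N+](=O)[O-])cc21` is still unmeasured and differs from compound 2 as follows: trifluoromethyl in place of methyl on a saturated ring carbon. Among the compounds with values here, the only measured step, a 7.9-fold higher number from compound 1 to compound 2 (0.90 log units; beyond the scatter), lies on a double-bonded ring carbon, so it offers a rough scale for a single change but no direction for this one. Within the data shown here, no measured step touches the saturated ring carbon. In this assay, a change smaller than that step is expected, with no clear direction and possibly none beyond the scatter. The estimated step is a 1.3-fold lower number from compound 2 to compound 3 (0.13 log units; within the scatter). For compound 3 the estimate is 8 nM, with an expected range from 2.5 nM to 35 nM.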

Compound 3, half-maximal effective concentration: 2.69 nM
The estimate for compound 3 lay 3.0-fold (0.47 log units) above the measured number, and the stated range covers the measured number.
By their numbers in this assay, from the lowest: compounds 1 and 3 (each within the scatter of the next); then compound 2.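

In this assay, within the data shown here, the saturated ring carbon next to the ring oxygen proves responsive: trifluoromethyl in place of methyl gives a 4.0-fold lower number from compound 2 to compound 3 (0.60 log units; beyond the scatter), a step on a part of the core that the earlier compounds left unchanged. The change in this step runs toward a lower number, so the entering group of 4 heavy atoms is tolerated here in place of a single carbon, with no loss in this assay. Nothing measured here accounts for the size or the direction of this step.

Going by these compounds, whether an ethyl group or a second trifluoromethyl on this carbon would extend the step remains open. Also open, on these data alone, is whether trifluoromethyl in place of methyl would shift the number in the same way on compound 1, with its sulfur-bearing group.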